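Compound 1 to compound 3: a dihydroxyphenyl swap

The source may report more compounds than this note shows. Statements on the series, on what has been measured and on what is new or still open speak of the compounds shown alone.

Among the measured compounds shown here, in an ADME assay on K562 cells (Homo sapiens) for cytotoxicity, with a stated time of 72 h (on this read-out lower numbers stand for stronger inhibition and higher numbers for weaker inhibition), compound 1 (`COc1ccccc1CNc1ncnc2c1ncn2C1CCCCO1`) gives 97000 nM, the higher of the two numbers so far, and compound 2 (`COc1ccc(OC)c(CNc2ncnc3c2ncn3C2CCCCO2)c1`) gives 16500 nM. Compound 3 (`Oc1cccc(CNc2ncnc3c2ncn3C2CCCCO2)c1O`) remains unmeasured and differs from compound 1 as follows: 2,3-dihydroxyphenyl in place of 2-methoxyphenyl on a saturated chain carbon bound to a nitrogen on an aromatic ring. For the measured compounds named here, the only measured step (a 5.9-fold lower number from compound 1 to compound 2 (0.77 log units; beyond the scatter)) is modest and comes from methoxy in place of hydrogen on an aromatic carbon, so it bears only indirectly on this change. A modest step towards a lower number is expected (a 3.2-fold lower number from compound 1 to compound 3 (0.51 log units; beyond the scatter)), with wide uncertainty. Compound 3 is estimated at 30000 nM (7000 nM to 100000 nM).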

Compound 3, half-maximal inhibitory concentration: 92000 nM
The estimate for compound 3 lay 3.1-fold (0.49 log units) below the measured number; the range from low to high includes it.
By their numbers in this assay, from the lowest: compound 2; then compounds 3 and 1 (each within the scatter of the next).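

At this position, on a saturated chain carbon bound to a nitrogen on an aromatic ring, 2,3-dihydroxyphenyl in place of 2-methoxyphenyl gives a 1.1-fold lower number from compound 1 to compound 3 (0.02 log units; within the scatter) in this assay, so compound 1 and compound 3 stand within the scatter of each other. This exchange brings 2 hydrogen-bond donors where the leaving group has 0, with no step beyond the scatter, unlike a 5.9-fold lower number from compound 1 to compound 2 (0.77 log units; beyond the scatter), the methoxy change. No available evidence bears on the reason for this result.

Open, as far as these compounds go, is whether a single hydroxyl, an amine or a carboxylic acid on the phenyl ring would match compound 3 or compound 2.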